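The compounds below may be only part of what the source reports. "The series", "measured", "known", "first", "only" and "open" are said of these compounds alone.

Measured compounds:
Compound 1 `CCCNC(=O)c1c(CN(CC)Cc2ccccc2)nc2ccccc2c1-c1ccccc1` gives 872 nM in an assay on brain with Translocator protein (Rattus norvegicus) as the target; a lower number here means a stronger inhibitor, a higher number a weaker inhibitor.
Compound 2 `CCN(Cc1ccccc1)Cc1nc2ccccc2c(-c2ccccc2)c1C(=O)N(C)C` gives 229 nM in this assay.
Compound 3 `CCN(Cc1ccccc1)Cc1nc2ccccc2c(-c2ccccc2)c1C(=O)NCc1ccccc1` gives 2900 nM in this assay.

Compound 3 has the highest number of the three, that is, the weakest binding: a 3.3-fold higher number from compound 1 to compound 3 (0.52 log units; beyond the scatter), and a 13-fold higher number from compound 2 to compound 3 (1.10 log units; beyond the scatter). Compound 4 `CCN(Cc1ccccc1)Cc1nc2ccccc2c(-c2ccccc2)c1C(=O)N(C)c1ccc(Cl)cc1` is not yet measured. It differs from compound 3 in one place: (4-chlorophenyl)(methyl)amino in place of benzylamino on a carbonyl carbon. The bearing of the measured steps is indirect. All three change the same amide: a 3.8-fold lower number from compound 1 to compound 2 (0.58 log units; beyond the scatter), which shows that a tertiary amide carrying two methyl groups gave the lowest number of the set, and a 13-fold higher number from compound 2 to compound 3 (1.10 log units; beyond the scatter), which shows that a benzylamino group raised it strongly. Compound 4 returns to a tertiary amide, keeping one methyl, yet carries an aromatic ring with a chlorine, a kind of group not covered by the measured set. In this assay compound 4 is therefore expected to give a lower number than compound 3, a step of about a 7.3-fold lower number from compound 3 to compound 4 (0.86 log units; beyond the scatter), with wide uncertainty: estimated 400 nM, between 80 nM and 2000 nM.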

Compound 4, half-maximal inhibitory concentration: 2480 nM
For compound 4 the middle estimate is 6.2-fold (0.79 log units) below the measured one, outside the stated range (above it).
By their numbers in this assay, from the lowest: compound 2; then compound 1; then compounds 4 and 3 (each within the scatter of the next).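

In this assay, putting (4-chlorophenyl)(methyl)amino in place of benzylamino on the carbonyl carbon gives a 1.2-fold lower number from compound 3 to compound 4 (0.07 log units; within the scatter) and so no readable change, even though the amide hydrogen is gone. Losing that hydrogen is therefore not enough to reach the low number of compound 2: 4-chlorophenyl in place of methyl on the amide-type nitrogen gives an 11-fold higher number from compound 2 to compound 4 (1.03 log units; beyond the scatter) and the same amide compared with propylamino gives a 2.8-fold higher number from compound 1 to compound 4 (0.45 log units; beyond the scatter) in this set. Among these four compounds, the two amides carrying a benzyl or 4-chlorophenyl group have the highest numbers, with or without the amide hydrogen, and no data here explain why.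

Still open, going by these compounds, is how much of the rise from compound 2 belongs to the chlorine and how much to the ring, which a methyl(phenyl)amino group would help separate. Also open, on these data alone, is whether another small tertiary amide, such as diethylamino, would stay as low as compound 2.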